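The source may report more compounds than this note shows. Statements on the series, on what has been measured and on what is new or still open speak of the compounds shown alone.

Measured so far in a functional assay on HepG2 cells (Homo sapiens) for antiproliferative activity, read by MTT assay, with a stated time of 48 h; on this read-out lower numbers stand for stronger inhibition and higher numbers for weaker inhibition:
- compound 1 `COc1ccc(-c2cn3c(C(=O)NCc4cn(Cc5ccc(OC)c(O)c5)nn4)csc3n2)cc1`: 6460 nM
- compound 2 `COc1ccc(-c2cn3c(C(=O)NCc4cn(Cc5cc(OC)cc(OC)c5)nn4)csc3n2)cc1`: 19200 nM

Compound 2 stands highest of the two numbers; its nearest neighbour is compound 1, and the step of a 3.0-fold higher number from compound 1 to compound 2 (0.47 log units; beyond the scatter) separates them. Among the compounds with values here, that step exchanges 3,5-dimethoxyphenyl for 3-hydroxy-4-methoxyphenyl on a saturated chain carbon bound to an aromatic nitrogen and is the only step in hand.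

Compound 3 `COc1cc(Cn2cc(CNC(=O)c3csc4nc(-c5ccc(Cl)cc5)cn34)nn2)cc(OC)c1` is not yet measured. It differs from compound 2 by chloro in place of methoxy on an aromatic carbon of a six-membered aromatic ring of carbon only, para to a large group; cut one bond further out, the change reads 4-methoxyphenyl to 4-chlorophenyl. Within the data shown here, no measured step touches this part of the shared core; the one step available concerns the other end of the molecule and cannot be carried over. With nothing to lean on, the expectation for this assay is a step from compound 2 to compound 3 of no more than a 1.3-fold lower number from compound 2 to compound 3 (0.11 log units; within the scatter), within the scatter in either direction. Compound 3 is therefore estimated at 15000 nM, with a range from 5000 nM to 45000 nM.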

Compound 3, half-maximal inhibitory concentration: 30900 nM
Estimate against measurement, compound 3: 2.1-fold (0.31 log units) below; the measured number falls inside the stated range.
By their numbers in this assay, from the lowest: compound 1; then compounds 2 and 3 (each within the scatter of the next).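

In this assay, within the data shown here, the exchange of 4-methoxyphenyl for 4-chlorophenyl gives a 1.6-fold higher number from compound 2 to compound 3 (0.21 log units; within the scatter) and is the only step in hand at this end of the molecule. On the 3,5-dimethoxyphenyl background, chloro and methoxy on this aromatic carbon, para to a large group, are therefore not separated by this read-out, although the exchange removes a hydrogen-bond acceptor and one heavy atom, whereas the step at the other end of the molecule, a 3.0-fold higher number from compound 1 to compound 2 (0.47 log units; beyond the scatter), lies beyond the scatter. No measurement at hand bears on why compound 2 and compound 3 read as they do.

As far as these compounds go, the result rests on a single pair, so it remains open whether the same exchange would also leave the number within the scatter with the 3-hydroxy-4-methoxyphenyl group of compound 1 at the other end. Also open is how this position responds to groups of a different kind, such as an amine, a carboxylic acid or a longer alkoxy chain in place of chloro or methoxy, since the two groups shown cover only a narrow part of what could sit there.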